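Adding a fluorine to a urea-linked thienopyrimidine

A few compounds are considered here, and "the series" means these few. Any claim that something is new, unique, unknown or untested is made for them only; others in the source may bear on it.

Of the compounds shown here, two of a shared core have been measured. Compound 1 `CN(C)CCNc1nc(-c2ccc(NC(=O)Nc3ccc(F)cc3)cc2)nc2c(Cl)c(Cl)sc12` and compound 2 `CCN(CC)CCCNc1nc(-c2ccc(NC(=O)Nc3ccccc3)cc2)nc2c(Cl)c(Cl)sc12` differ in two places at once: in the amine chain on the core and in whether the outer phenyl ring of the urea carries a fluorine. In a functional assay on NCI-H460 cells (Homo sapiens) for cytotoxicity, read by MTT assay, with a stated time of 72 h (a lower number here means a stronger inhibitor, a higher number a weaker inhibitor), compound 1 gives 590 nM, and compound 2 gives 850 nM. Compound 2 thus has the higher of the two numbers, but the gap to compound 1 lies within the scatter of this assay, so nothing separates them with confidence.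

Compound 3 `CCN(CC)CCCNc1nc(-c2ccc(NC(=O)Nc3ccc(F)cc3)cc2)nc2c(Cl)c(Cl)sc12` keeps the amine chain of compound 2 and changes only one thing: fluoro in place of hydrogen on an aromatic carbon, para to a large group. Within the data shown here, no single-change step between measured compounds exists to show what this does here. With only the two values to go on, the step is expected to be small, and the estimated step of a 1.2-fold lower number from compound 2 to compound 3 (0.08 log units; within the scatter) stays within the scatter, perhaps slightly toward a lower number. Compound 3 is therefore expected to give about 700 nM in this assay, with a range from 300 nM to 1600 nM.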

Compound 3, half-maximal inhibitory concentration: 450 nM
For compound 3 the middle estimate is 1.6-fold (0.19 log units) above the measured one, within the range that was stated.
By their numbers in this assay, from the lowest: compounds 3, 1 and 2 (each within the scatter of the next).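

In this assay the change from phenyl to 4-fluorophenyl on the urea can now be read on its own, as a 1.9-fold lower number from compound 2 to compound 3 (0.28 log units; within the scatter) with the amine chain held fixed, so fluoro and hydrogen at this aromatic carbon cannot be told apart with confidence. Among these compounds, the amine chain can also be read on its own for the first time, as a 1.3-fold lower number from compound 1 to compound 3 (0.12 log units; within the scatter) with the 4-fluorophenyl group held fixed, so these two chains cannot be told apart with confidence either, and neither single change shows a clear effect on the cytotoxicity read-out. No separate measurement is available to explain either step.

Going by these compounds, it remains open whether a larger or different group at this same aromatic carbon, such as chloro, methoxy or trifluoromethyl, would give a step beyond the scatter, which would show whether this position responds to change at all. On these data alone, it is equally open whether a longer chain, or a ring amine such as morpholine at the end of the chain, would separate itself from the two chains seen so far.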